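Swapping the amidine substituent on a shared core

The compounds below may be only part of what the source reports. "The series", "measured", "known", "first", "only" and "open" are said of these compounds alone.

Three compounds share one core. Compound 1 `Nc1nc2c(c(=O)n(CC3CC3)c(=O)n2CC2CC2)n1S(=O)(=O)c1ccc(C(F)(F)F)cc1` gives 0% in an assay on isolated protein with dual specificity calcium/calmodulin-dependent 3',5'-cyclic nucleotide phosphodiesterase 1B (Bos taurus) as the target, tested at 100 uM; a higher number here means more inhibition at the concentration tested (going by the name of the read-out), a lower number less inhibition. Compound 2 `COc1ccc(OC)c(S(=O)(=O)n2c(N)nc3c2c(=O)n(CC2CC2)c(=O)n3CC2CC2)c1` differs from compound 1 only in its sulfonyl aryl group. Compound 2 gives 31%. That change was a number 31 percentage points higher from compound 1 to compound 2 (beyond the scatter). Compound 3 `CN(C)/C=N/c1nc2c(=O)n(CC3CC3)c(=O)n(CC3CC3)c2[nH]1` gives 7%. Among these three numbers compound 3 and compound 1 lie within the scatter of each other, while compound 2 lies beyond the scatter, higher than compound 3.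

Compound 4 `CC(C)(C)/N=C\Nc1nc2c(=O)n(CC3CC3)c(=O)n(CC3CC3)c2[nH]1` has not been measured. It differs from compound 3 by a group of 7 heavy atoms (5 carbon, 2 nitrogen; no ring) in place of a group of 5 heavy atoms (3 carbon, 2 nitrogen; no ring), on an aromatic carbon. For the measured compounds named here, no measured step involves this position: the only measured step, between compound 1 and compound 2, concerns the sulfonyl aryl group, which compounds 3 and 4 lack entirely. Going by the values given here, there is thus nothing among the measured steps that speaks to the exchange between compound 3 and compound 4, and the expected step is none beyond the scatter, a number 1 percentage points higher from compound 3 to compound 4 (within the scatter) being the estimated change.

Compound 4 is therefore expected to give about 8% in this assay, with an estimated range from 0% to 25%.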

Compound 4, a percentage reported as inhibition, at one concentration (the size of the read-out at that concentration, not a potency): 11%
For compound 4 the middle estimate is 3 percentage points below the measured one; the range from low to high includes it.
By their numbers in this assay, from the lowest: compounds 1, 3 and 4 (each within the scatter of the next, the first and the last beyond it); then compound 2.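

In this assay, for the compounds shown here, the first measured step at this position, on an aromatic carbon of a five-membered aromatic ring with 2 nitrogen, is a number 4 percentage points higher from compound 3 to compound 4 (within the scatter). The group of 7 heavy atoms, which carries 1 hydrogen-bond donor, and the group of 5 heavy atoms, which carries 0 hydrogen-bond donors, therefore cannot be told apart by this read-out, with compound 3 at 7% and compound 4 at 11%, both percentages taken at a single concentration and not potencies. Nothing available accounts for this result.

The compounds shown leave open whether a different kind of group on this aromatic carbon, such as a carboxylic acid or a longer carbon chain in place of the group of 7 heavy atoms, would give a number beyond the scatter from that of compound 3. They also leave open what happens in this assay when the group of 7 heavy atoms and a sulfonyl aryl group such as 2,5-dimethoxyphenyl sulfonyl stand together on the shared core.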